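Replacing the 2,3,4-trimethoxyphenyl group of compound 2

A few compounds are considered here, and "the series" means these few. Any claim that something is new, unique, unknown or untested is made for them only; others in the source may bear on it.

In a functional assay on PC-3 cells (Homo sapiens) for cytotoxicity, read by MTT assay, with a stated time of 72 h (on this read-out higher numbers stand for weaker inhibition and lower numbers for stronger inhibition), compound 1 `COc1ccc(/C=C/C(=O)Nc2cc3c(Nc4ccc(F)c(Cl)c4)ncnc3cc2O[C@H]2CCOC2)c(OC)c1` gives 2760 nM and compound 2 `COc1ccc(/C=C/C(=O)Nc2cc3c(Nc4ccc(F)c(Cl)c4)ncnc3cc2O[C@H]2CCOC2)c(OC)c1OC` gives 7670 nM, the higher and therefore weaker of the two results. Compound 3 `COc1cc(/C=C/C(=O)Nc2cc3c(Nc4ccc(F)c(Cl)c4)ncnc3cc2O[C@H]2CCOC2)cc(OC)c1O` differs from compound 2 as follows: 4-hydroxy-3,5-dimethoxyphenyl in place of 2,3,4-trimethoxyphenyl on a double-bonded chain carbon bound to a double-bonded chain carbon. For the measured compounds named here, one measured step bears on this change only loosely: a 2.8-fold higher number from compound 1 to compound 2 (0.44 log units; beyond the scatter), a modest rise when methoxy replaced hydrogen on an aromatic carbon. Going by the values given here, no measurement yet shows what a hydroxy group does here, so the expectation is uncertain. A similarly modest fall is expected, a 2.2-fold lower number from compound 2 to compound 3 (0.34 log units; beyond the scatter). For compound 3 the estimated value is 3500 nM, within an expected range of 1300 nM to 8500 nM.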

Compound 3, half-maximal inhibitory concentration: 26500 nM
Compound 3: middle estimate off by 7.6-fold (0.88 log units), on the low side; measured number outside the range, above it.
By their numbers in this assay, from the lowest: compound 1; then compound 2; then compound 3.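

In this assay, the 4-hydroxy-3,5-dimethoxyphenyl group brings a 3.5-fold higher number from compound 2 to compound 3 (0.54 log units; beyond the scatter) and also a 9.6-fold higher number from compound 1 to compound 3 (0.98 log units; beyond the scatter), making compound 3 the weakest of the three. For the compounds shown here, it is also the only compound of the three with a hydrogen-bond donor on this ring, so adding a methoxy group is not the only change here that weakens the result. Nothing available explains this loss.

These compounds do not separate the effect of the hydroxy group from that of the rearranged methoxy groups. From the compounds shown here alone, how an amine in place of that hydroxy would behave also remains open.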